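The source may hold more compounds than are shown below. What is called first, only, known or untested is meant among the compounds shown, and "the series" means these compounds.

Compounds measured so far:
compound 1 `CCOC(=O)c1cnc(N2CCN(Cc3ccccc3C(=O)OC)CC2)nc1Oc1c(C)cc(-c2ccc(C#N)cc2)cc1C` — > 125000 nM
compound 2 `CCOC(=O)c1cnc(N2CCN(Cc3cccc(C(N)=O)c3)CC2)nc1Oc1c(C)cc(-c2ccc(C#N)cc2)cc1C` — 14800 nM

In an ADME assay on MT4 cells (Homo sapiens) for cytotoxicity, read by MTT assay, with a stated time of 4 days (on this read-out lower numbers stand for higher toxicity in this test and higher numbers for lower toxicity in this test), compound 1 reaches only a limit, > 125000 nM. For the measured compounds named here, compound 2 is the only numbered value in this assay, 14800 nM. Compound 3 `CCOC(=O)c1cnc(N2CCN(Cc3cccc(OC)c3)CC2)nc1Oc1c(C)cc(-c2ccc(C#N)cc2)cc1C` differs from compound 2 by methoxy in place of carbamoyl on an aromatic carbon. Going by the values given here, the single measured step, an at least 8.4-fold lower number from compound 1 to compound 2 (0.92 log units; beyond the scatter), concerns a different replacement on the same ring and bears only loosely on this change, since the limit of > 125000 nM in this assay, at which 1 of the 2 values shown sits, leaves its true size open. Among the compounds with values here, no step in this assay tests methoxy itself. Compound 3 is therefore expected near compound 2, a 1.7-fold higher number from compound 2 to compound 3 (0.23 log units; within the scatter), giving an estimate of 25000 nM with a range from 8000 nM to 125000 nM.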

Compound 3, half-maximal cytotoxic concentration: > 125000 nM
Compound 3: no number, only a limit; the forecaster's own chance of this, stated with the estimate: 25%; at least 5.0-fold (0.69 log units) between middle value and limit.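

In this assay, methoxy in place of carbamoyl on an aromatic carbon gives an at least 8.4-fold higher number from compound 2 to compound 3 (0.92 log units; beyond the scatter), so the read-out at this position responds to the change. Of the three compounds, only compound 2, which carries carbamoyl, gives a number. Compound 3 gives > 125000 nM, which is a limit, and the step between the limits of compound 1 and compound 3 cannot be read.

On these data alone, how far the number rises with methoxy stays open: the limit of > 125000 nM in this assay, at which 2 of the 3 values shown sit. Also open, as far as these compounds go, is where an amine or a carboxylic acid on this aromatic carbon would fall.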